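Compound 1 loses its carbamoyl group

The source may report more compounds than this note shows. Statements on the series, on what has been measured and on what is new or still open speak of the compounds shown alone.

Values in an in vitro ADME assay on microsomes from liver (Homo sapiens) for metabolic stability; on this read-out higher numbers stand for fast clearance and lower numbers for slow clearance (both are limits):
- compound 1 `NC(=O)c1n[nH]c(-c2nc(Cc3ccccc3F)c3ccccn23)n1` gives < 8 mL.min-1.g-1 as a limit
- compound 2 `Cc1ncc(Cn2nc(-c3nc(C(F)(F)F)n[nH]3)c3cccnc32)cn1` gives < 7 mL.min-1.g-1 as a limit

Compound 1 has no exact place on this scale, since its reading (< 8 mL.min-1.g-1) is a limit and not a number. The same holds for compound 2, whose reading (< 7 mL.min-1.g-1) is also a limit. The two compounds therefore cannot be ranked against each other.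

Compound 3 `Fc1ccccc1Cc1nc(-c2ncn[nH]2)n2ccccc12` differs from compound 1 by hydrogen in place of carbamoyl on an aromatic carbon, which turns 3-carbamoyl-1H-1,2,4-triazol-5-yl to 1H-1,2,4-triazol-5-yl. Among the compounds with values here, no measured pair shows this change. The expected step in this assay is small and upward, estimated as (an at least 1.1-fold higher number from compound 1 to compound 3 (0.05 log units; that floor lies within the scatter)), and hardly beyond the scatter. Compound 3 is expected at (9 mL.min-1.g-1), with an estimated range of (4 mL.min-1.g-1 to 22 mL.min-1.g-1).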

Compound 3, intrinsic clearance in microsomes: 175 mL.min-1.g-1
For compound 3 the middle estimate is 19-fold (1.29 log units) below the measured one, and the stated range ends below it.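

In this assay, hydrogen in place of carbamoyl on this aromatic carbon gives an at least 21-fold higher number from compound 1 to compound 3 (1.33 log units; beyond the scatter), which shows that the group at this position has a large bearing on the read-out within the core of compound 1. The true size of the step may be greater, and the printed figure is only a floor because compound 1 stands at a limit: the limit of < 8 mL.min-1.g-1 in this assay, at which 1 of the 3 values shown sits. Compound 2 differs from these compounds in more than one place, so it does not isolate this change.

From the compounds shown here alone, what remains open is whether the low reading depends on carbamoyl itself or whether a methyl, an amine or a carboxylic acid on this carbon would serve as well. The compounds shown also do not tell why the change has so large an effect, or whether it would be as large on another core.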